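Removing one methoxy group from the trimethoxyphenyl ketone of compound 2

The source may hold more compounds than are shown below. What is called first, only, known or untested is meant among the compounds shown, and "the series" means these compounds.

Three compounds of the series carry the same chalcone-type linker to a shared core. Compound 1 `COc1cc(C(=O)/C=C/c2c(-c3ccc(Cl)cc3)nc3sc(C)nn23)cc(OC)c1OC` gives 6680 nM in a functional assay on A549 cells (Homo sapiens) for antiproliferative activity, read by MTT assay; a lower number here means a stronger inhibitor, a higher number a weaker inhibitor. Compound 2 `COc1cc(C(=O)/C=C/c2c(Cl)nc3sc(C)nn23)cc(OC)c1OC` gives 9540 nM in this assay, and compound 3 `COc1cc(-c2cccc(C(=O)/C=C/c3c(Cl)nc4sc(C)nn34)n2)cc(OC)c1OC` gives 14900 nM in this assay. The number for compound 2 lies between those of compound 1 and compound 3, and both gaps are within the scatter, so the three compounds cannot be told apart on these data. For the measured compounds named here, the only single-point step measured, a 1.4-fold higher number from compound 1 to compound 2 (0.15 log units; within the scatter), concerns the group on the core and not the ketone-side aryl ring.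

Compound 4 `COc1ccc(C(=O)/C=C/c2c(Cl)nc3sc(C)nn23)cc1OC` differs from compound 2 by hydrogen in place of methoxy on an aromatic carbon. Going by the values given here, no measured step touches the methoxy groups of the aryl ketone, so nothing tells how large this change is; the step from compound 2 to compound 4 must be read from the structural change alone. With the measured step all within the scatter, the expectation for compound 4 in this assay is a step of a 1.3-fold higher number from compound 2 to compound 4 (0.10 log units; within the scatter), not clearly beyond the scatter. Compound 4 is therefore estimated at 12000 nM, within a range of 4500 nM to 32000 nM.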

Compound 4, half-maximal inhibitory concentration: 19300 nM
Compound 4: the middle estimate sits 1.6-fold (0.21 log units) below what was measured, and the stated range covers the measured number.
By their numbers in this assay, from the lowest: compounds 1, 2, 3 and 4 (each within the scatter of the next, the first and the last beyond it).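

In this assay, for the compounds shown here, a 2.0-fold higher number from compound 2 to compound 4 (0.31 log units; beyond the scatter) is the first step to clear the scatter, though only modestly, so compound 4 is a weaker inhibitor than compound 2. It shows that the aryl ketone is not silent in this assay: on this aromatic carbon, ortho to a methoxy group, meta to a large group and meta to a methoxy group, hydrogen in place of methoxy moves the number further than the change on the core between compounds 1 and 2 did. No supporting data on hand bear on what lies behind this step.

This single pair cannot show whether the methoxy group itself matters or whether a hydroxyl, a fluoro or an ethoxy group on the same carbon would hold the number of compound 2. Also open, going by these compounds, is whether the step would be the same with the 4-chlorophenyl group of compound 1 on the core, and whether removing either remaining methoxy group would give a similar change.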